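The compounds below may be only part of what the source reports. "The series", "measured", "known", "first", "only" and "open" are said of these compounds alone.

In a functional assay on DU-145 cells (Homo sapiens) for inhibition, read by trypan blue exclusion, with a stated time of 96 h (on this read-out higher numbers stand for weaker inhibition of growth and lower numbers for stronger inhibition of growth), compound 3 (`COc1ccccc1/C=C(/SCc1ccc(F)cc1)C(=O)c1ccc(Cl)cc1`) gives 10000 nM. Compound 1 (`COc1ccccc1/C=C(/SCc1ccc(F)cc1)C(=O)c1ccc(Br)cc1`) stands level with it at 10000 nM, and the two share the highest of the three numbers. Compound 2 (`COc1ccc(/C=C(/Sc2ccc(C)cc2)C(=O)c2ccc(Cl)cc2)cc1O`) has the lowest number, 1000 nM.

The next compound, compound 4 (`COc1ccccc1/C=C(/Sc1ccc(C)cc1)C(=O)c1ccc(Cl)cc1`), has 4-methylphenyl in place of 4-fluorobenzyl on a sulfur. Going by the values given here, the only measured step between compounds that differ in one place is no change at the digits printed from compound 1 to compound 3 (within the scatter). Among the compounds with values here, it concerns chloro in place of bromo, so it says nothing directly about the group on sulfur, and no measured step isolates that change.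

Within the data shown here, the nearest indirect evidence is compound 2, the only measured compound with 4-methylphenyl on a sulfur, at 1000 nM. However, it also differs from compound 4 elsewhere in the structure, so only part of its lower number can reasonably be expected to carry over. On that basis, a moderate move toward stronger inhibition of growth is expected, and the estimated step is a 2.5-fold lower number from compound 3 to compound 4 (0.40 log units; beyond the scatter), although a result level with compound 3 would not be surprising. The estimate for compound 4 is 4000 nM, with an expected range from 1200 nM to 10000 nM.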

Compound 4, concentration for 50% growth inhibition: 25000 nM
Compound 4: the middle estimate sits 6.3-fold (0.80 log units) below what was measured; the measured number lies above the stated range.
By their numbers in this assay, from the lowest: compound 2; then compounds 1 and 3 (each within the scatter of the next); then compound 4.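

In this assay, going by these compounds alone, the change from 4-fluorobenzyl to 4-methylphenyl on a sulfur gives a 2.5-fold higher number from compound 3 to compound 4 (0.40 log units; beyond the scatter) and so provides the first direct reading at this position, where the new group goes with weaker inhibition of growth on this core. The low number of compound 2 therefore did not come from 4-methylphenyl on a sulfur alone, since with that group held constant, 2-methoxyphenyl in place of 3-hydroxy-4-methoxyphenyl on a double-bonded chain carbon bound to a double-bonded chain carbon gives a 25-fold higher number from compound 2 to compound 4 (1.40 log units; beyond the scatter) and this large step far outweighs the modest one at the sulfur. Nothing available here accounts for either step.

From the compounds shown here alone, whether 3-hydroxy-4-methoxyphenyl brings a similar gain with 4-fluorobenzyl on the sulfur remains open, as the two changes are seen together only with 4-methylphenyl. It is also unknown how this read-out would respond to an amine or a longer chain in place of these groups on the sulfur.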